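Shrinking the amine on the core of compound 2

The source may report more compounds than this note shows. Statements on the series, on what has been measured and on what is new or still open speak of the compounds shown alone.

Of the compounds shown here, two sharing one core have been measured in an assay on CHO cells for displacement of a labelled ligand from adenosine receptor A1 (Homo sapiens); on this read-out lower numbers stand for stronger inhibition and higher numbers for weaker inhibition. Compound 1 `COc1ccc(CNc2ncc(C(=O)O)c3nc(-c4ccco4)nn23)cc1OC` gives 958 nM. Compound 2 `CCOC(=O)c1cnc(NCC2CCCCC2)n2nc(-c3ccco3)nc12` gives 432 nM, the lower of the two numbers; the gap from compound 1 to compound 2 is beyond the usual scatter, so compound 2 stands as the stronger binder of the pair. No single change links compounds 1 and 2, so their values are simply noted side by side.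

Compound 3 `CCOC(=O)c1cnc(N(C)C)n2nc(-c3ccco3)nc12` differs from compound 2 in one place: dimethylamino in place of (cyclohexylmethyl)amino on an aromatic carbon. This change removes the only ring outside the core on that side and the hydrogen-bond donor with it. Since compound 2 gives 432 nM with the larger group in place, the smaller group in compound 3 is expected to weaken binding by a modest step, a 4.6-fold higher number from compound 2 to compound 3 (0.67 log units; beyond the scatter), beyond the scatter. Compound 3 is therefore estimated at 2000 nM, within a range from 500 nM to 8000 nM.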

Compound 3, inhibition constant: 13400 nM
Compound 3: middle estimate off by 6.7-fold (0.83 log units), on the low side; measured number above the stated range.
By their numbers in this assay, from the lowest: compound 2; then compound 1; then compound 3.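

In this assay, among the compounds shown here, this position on the shared core proves highly sensitive: dimethylamino in place of (cyclohexylmethyl)amino gives a 31-fold higher number from compound 2 to compound 3 (1.49 log units; beyond the scatter), a large loss of binding that the earlier compounds, linked by no single change, could not show. The swap removes the six-membered carbon ring and the hydrogen-bond donor together, so this one step cannot separate what each contributes. Nothing measured here explains the loss.

Going by these compounds, it remains open whether the ring, the amine hydrogen or simply the overall size of the group matters most. A methylamino group would keep the amine hydrogen without the ring, while a piperidine ring attached through its nitrogen would keep a ring without that hydrogen, and the values of such compounds on this aromatic carbon would help tell these possibilities apart.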